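Same atoms, two stereocentres flipped: compound 4 awaits its number

The source may hold more compounds than are shown below. What is called first, only, known or untested is meant among the compounds shown, and "the series" means these compounds.

compound 1 `O=C(NCc1cc(Cl)ccc1-n1cnnn1)[C@@H]1[C@H]2C[C@H]2CN1C(=O)[C@H](O)c1ccccc1` gives 61 mL.min-1.g-1
compound 2 `CC(C)(C)C[C@@H](O)C(=O)N1C[C@@H]2C[C@@H]2[C@H]1C(=O)NCc1cc(Cl)ccc1-n1cnnn1` gives 20 mL.min-1.g-1
compound 3 `O=C(NCc1cc(Cl)ccc1-n1cnnn1)[C@@H]1[C@H]2C[C@H]2CN1C(=O)[C@H](O)C1CCCCC1` gives 110 mL.min-1.g-1

These numbers come from an ADME assay on liver for metabolic stability, with Liver microsome (Homo sapiens) as the target, read by LC-MS, using microsomes (a lower number here means slower removal, a higher number faster removal of the compound), and the three compounds differ in a single group on a shared core. Compound 1 sits with compound 3 at the upper end of the three numbers: a 1.8-fold higher number from compound 1 to compound 3 (0.26 log units; within the scatter) stays within the usual scatter, while a 3.1-fold lower number from compound 1 to compound 2 (0.48 log units; beyond the scatter) goes beyond it.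

The compound still to be measured is compound 4 `O=C(NCc1cc(Cl)ccc1-n1cnnn1)[C@@H]1[C@@H]2C[C@@H]2CN1C(=O)[C@H](O)c1ccccc1` and its relation to compound 1 is simple to state: the two compounds have the same atoms and bonds and differ only in configuration as drawn: 2 of 4 stereo elements differ; a stereocentre at a saturated ring carbon is drawn S in compound 1 and R in compound 4; a stereocentre at a saturated ring carbon is drawn R in compound 1 and S in compound 4 and nothing else changes. Within the data shown here, none of the measured steps tests a change of this kind, since each swaps one group for another and none alters a configuration. They show only how far the number moves within this small set, and the largest is a 5.5-fold higher number from compound 2 to compound 3 (0.74 log units; beyond the scatter) in this series. The data offer no direction for a change in configuration, so no step beyond the scatter is expected, although a step as large as a 3.1-fold lower number from compound 1 to compound 2 (0.48 log units; beyond the scatter) in either direction remains possible. The expected step is a 1.0-fold lower number from compound 1 to compound 4 (0.01 log units; within the scatter) and it is only an estimate. For compound 4 the estimated value is 60 mL.min-1.g-1 with an expected range of 22 mL.min-1.g-1 to 160 mL.min-1.g-1 in this assay once it is measured.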

Compound 4, intrinsic clearance in microsomes: < 15 mL.min-1.g-1
Compound 4 ended at the assay's limit; the forecaster's own chance of this, stated with the estimate: 3%; middle value at least 4.0-fold (0.60 log units) from the limit.
By their numbers in this assay, from the lowest: compound 2; then compounds 1 and 3 (each within the scatter of the next). At a limit, below all of these: compound 4.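

In this assay, among these compounds, the earlier compounds showed only what happens when one group on the chain carbon is swapped for another, whereas this result shows that configuration in the shared core can also shift the number, with no change of group: an at least 4.0-fold lower number from compound 1 to compound 4 (0.60 log units; beyond the scatter). The value for compound 4, < 15 mL.min-1.g-1, is a limit and not a number, so this step has a fixed end only at compound 1: the limit of < 15 mL.min-1.g-1 in this assay, at which 1 of the 4 values shown sits. Nothing enters or leaves, so the step belongs entirely to the two saturated ring carbons whose drawn configurations are reversed: the fact that compounds 1 and 4 differ only in the configuration as drawn.

The compounds shown do not separate the two ring carbons, as both are reversed together in compound 4, so it remains open whether one of them alone would give a step of this size. It also remains open whether the reversed core would give a similar step with the neopentyl of compound 2, the cyclohexyl of compound 3, or a group not shown here, such as an amine or a carboxylic acid, in place of the phenyl.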